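A few compounds are considered here, and "the series" means these few. Any claim that something is new, unique, unknown or untested is made for them only; others in the source may bear on it.

Compound 1 `Cc1ccc(C(=O)C(=C2NCCN2)c2c(Cl)c(F)c(C#N)c(F)c2C#N)cc1` and compound 2 `Cc1ccc(C(=O)C(=C2NCCN2)c2c(F)c(F)c(C#N)c(F)c2C#N)cc1` share one core and differ in a single place: fluoro in place of chloro on an aromatic carbon. In a functional assay on A-431 cells (Homo sapiens) for antiproliferative activity, read by MTT assay (on this read-out lower numbers stand for stronger inhibition and higher numbers for weaker inhibition), compound 1 gives 1.7 ug/mL, and compound 2 gives 0.5 ug/mL, a step of a 3.4-fold lower number from compound 1 to compound 2 (0.53 log units; beyond the scatter). Compound 3 `N#Cc1c(F)c(Cl)c(C(C(=O)c2ccc(F)cc2)=C2NCCCCN2)c(C#N)c1F` is built on another core, and the difference between the two cores is not broken down here. In this assay compound 3 gives 1.5 ug/mL. Compound 4 `N#Cc1c(F)c(F)c(C(C(=O)c2ccc(F)cc2)=C2NCCCCN2)c(C#N)c1F` differs from compound 3 by the same change, at the same kind of place: fluoro in place of chloro on an aromatic carbon. Within the data shown here, an expected step of a 3.0-fold lower number from compound 3 to compound 4 (0.48 log units; beyond the scatter) is taken here, because the only measured example of this change is a 3.4-fold lower number from compound 1 to compound 2 (0.53 log units; beyond the scatter). On that basis compound 4 is estimated at 0.5 ug/mL, most likely between 0.2 ug/mL and 1.2 ug/mL.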

Compound 4, half-maximal inhibitory concentration: 1.9 ug/mL
Beside the measured number, compound 4's estimate is 3.8-fold (0.58 log units) below it; measured number outside the range, above it.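

In this assay fluoro in place of chloro on an aromatic carbon gives a 1.3-fold higher number from compound 3 to compound 4 (0.10 log units; within the scatter) and so leaves compound 3 and compound 4 indistinguishable. The size of this change on one core is therefore no safe guide to its size on the other, though two cores cannot show why they part or how a third core would behave. The two steps disagree: the same change on two cores in this assay, a 3.4-fold lower number (0.53 log units; beyond the scatter) from compound 1 to compound 2 and a 1.3-fold higher number (0.10 log units; within the scatter) from compound 3 to compound 4, 4.3-fold (0.63 log units) apart, beyond the scatter of two such steps

Which of the differences between the two cores matters remains open. So does whether a bromo or a methoxy group in the same place would follow the pattern of compound 1 and compound 2 or that of compound 3 and compound 4.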